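Swapping an oxadiazolylphenyl for a benzodioxinyl: cytotoxicity outlook

A few compounds are considered here, and "the series" means these few. Any claim that something is new, unique, unknown or untested is made for them only; others in the source may bear on it.

Compound 1 (`CCOC(=O)CCCCCOc1cccc(CN(C(=O)c2ccc(-c3cccc(N(C)C)c3)cc2)C(C)C)c1`): in an ADME assay on HEK293 cells (Homo sapiens) for cytotoxicity, read by CellTiter-Glo and resazurin assay, with a stated time of 72 h (a higher number here means that more compound is needed for the effect, a lower number that less compound is needed), compound 1 gives > 26000 nM which is a limit of the assay and not a number.
Compound 2 (`CCOC(=O)CCCCCOc1cccc(CN(C(=O)c2ccc(-c3cccc(C(C)=O)c3)cc2)C(C)C)c1`): in this assay compound 2 gives > 26000 nM which is also a limit.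
Compound 3 (`CCOC(=O)CCCCCOc1cccc(CN(C(=O)c2ccc(-c3cccc(-c4nnc(C)o4)c3)cc2)C(C)C)c1`): in this assay compound 3 gives > 26000 nM which is again a limit.

So compound 3 stands at the top of what this assay reports, without a real number. The three values sit together: the limit of > 26000 nM in this assay, at which 3 of the 3 values shown sit, is all there is. Compound 4 (`CCOC(=O)CCCCCOc1cccc(CN(C(=O)c2ccc(-c3ccc4c(c3)OCCO4)cc2)C(C)C)c1`) differs from compound 3 in one place: 2,3-dihydro-1,4-benzodioxin-6-yl in place of 3-(5-methyl-1,3,4-oxadiazol-2-yl)phenyl on an aromatic carbon. Going by the values given here, the steps that bear on this part of the molecule (a step that the two limits leave unreadable from compound 1 to compound 3 and a step that the two limits leave unreadable from compound 2 to compound 3) and the step that the two limits leave unreadable from compound 1 to compound 2 cannot be sized at all. No readable step in this assay is therefore expected from the change, and the expected step is a step that the limit leaves unreadable from compound 3 to compound 4. Compound 4 is estimated at 40000 nM with a range from 15000 nM to 150000 nM and will most likely again be reported only as a limit.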

Compound 4, half-maximal effective concentration: > 24400 nM
Compound 4 ended at the assay's limit (the forecaster's own chance of this, stated with the estimate: 85%); the middle value is on the limit's open side.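

In this assay, going by these compounds alone, compound 4, like compound 1, compound 2 and compound 3, gives only a limit and not a number, so no step among them can be read. The compounds shown leave open what concentration of any of them would produce the cytotoxic effect.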